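Compound 3 and the cytotoxicity limit of the series

The source may hold more compounds than are shown below. What is called first, only, known or untested is meant among the compounds shown, and "the series" means these compounds.

Measured in an ADME assay on Raji cells (Homo sapiens) for cytotoxicity, read by luminescence, with a stated time of 72 h; a lower number here means that less compound is needed, a higher number that more compound is needed for the effect:
- Compound 1 `CCOC(=O)c1c(-c2cccc(OC(F)(F)F)c2)[nH]c2cc(OC)c(F)cc2c1=O`: > 21500 nM (a limit)
- Compound 2 `CCOC(=O)c1c(-c2cccc(Br)c2)[nH]c2cc(OC)c(F)cc2c1=O`: > 21500 nM (a limit)

For compound 2 the only result is > 21500 nM, which is a limit of the assay and not a number. Compound 3 `CCOC(=O)c1c(-c2cccc(Cc3nc(C)c(C)s3)c2)[nH]c2cc(OC)c(F)cc2c1=O` replaces the bromine of compound 2 with a larger group: a group of 8 heavy atoms (6 carbon, 1 nitrogen, 1 sulfur; one five-membered aromatic ring with 2 hetero atoms) in place of one bromine atom, on an aromatic carbon. Going by the values given here, the one measured step that bears on this position is a step that the two limits leave unreadable from compound 1 to compound 2, with bromo in place of trifluoromethoxy on an aromatic carbon. Its size cannot be read, so it offers no magnitude to carry over. The evidence amounts to the limit of > 21500 nM in this assay, at which 2 of the 2 values shown sit. Among the compounds with values here, no measured compound carries a group like the one entering here, so the numbers in this assay support no firm direction. The expectation is that compound 3 stays close to the same limit, with a smaller chance of a readable value under it. The expected step is an at least 1.0-fold lower number from compound 2 to compound 3 (0.03 log units; that floor lies within the scatter). The estimate for compound 3 is 20000 nM, expected to fall between 6000 nM and 40000 nM.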

Compound 3, half-maximal effective concentration: > 21500 nM
Compound 3 gave a limit, no number (the forecaster's own chance of this, stated with the estimate: 70%); at least 1.0-fold (0.03 log units) between middle value and limit.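

No step among compound 1, compound 2 and compound 3 can be read; each result is a limit and not a number, and what stands is: the limit of > 21500 nM in this assay, at which 3 of the 3 values shown sit.

Left open is whether any group on this aromatic carbon gives a readable value under that limit, and how the three compounds truly compare.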